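Replacing the Methyl on the Amino Nitrogen with Acetyl

The source may hold more compounds than are shown below. What is called first, only, known or untested is meant among the compounds shown, and "the series" means these compounds.

Compound 1, `CNc1cc2nc(-c3ccccc3)nn(-c3ccccc3)c-2cc1=O`: 690 nM
Compound 2, `CCN(CC)c1cc2nc(-c3ccccc3)nn(-c3ccccc3)c-2cc1=O`: > 5000 nM
Compound 3, `O=c1cc2n(-c3ccccc3)nc(-c3ccccc3)nc-2cc1N1CCCCC1`: 1980 nM

In a functional assay on MCF7 cells (Homo sapiens) for cytotoxicity, read by MTT assay, with a stated time of 72 h (a higher number here means a weaker inhibitor, a lower number a stronger inhibitor), compound 1 gives 690 nM, the lowest of the two plain numbers shown; compound 3 lies a 2.9-fold higher number from compound 1 to compound 3 (0.46 log units; beyond the scatter). For compound 2 the value is a limit of the assay, not a number, and the same is true of the limit of > 5000 nM in this assay, at which 1 of the 3 values shown sits. Compound 4, `CC(=O)Nc1cc2nc(-c3ccccc3)nn(-c3ccccc3)c-2cc1=O`, is not yet measured. It differs from compound 1 in one place: acetyl in place of methyl on a nitrogen on an aromatic ring. Two measured steps also replace the methylamino group with something larger, and both give weaker inhibitors: an at least 7.2-fold higher number from compound 1 to compound 2 (0.86 log units; beyond the scatter) and a 2.9-fold higher number from compound 1 to compound 3 (0.46 log units; beyond the scatter). A step of similar direction is therefore expected here, so compound 4 is estimated at 2000 nM, between 700 nM and 6000 nM. This expectation means a step of a 2.9-fold higher number from compound 1 to compound 4 (0.46 log units; beyond the scatter).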

Compound 4, half-maximal inhibitory concentration: > 5000 nM
Compound 4 was reported as a limit; the forecaster's own chance of this, stated with the estimate: 25%; at least 2.5-fold (0.39 log units) between middle value and limit.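

In this assay, the change to acetamido gives an at least 7.2-fold higher number from compound 1 to compound 4 (0.86 log units; beyond the scatter), so this position can lose activity even when its nitrogen keeps a hydrogen, as it does in compound 1 but not in compound 2 or compound 3. The acetamido group also does worse than piperidin-1-yl, with an at least 2.5-fold higher number from compound 3 to compound 4 (0.40 log units; beyond the scatter). The result for compound 4 is a limit, not a number, and its step with compound 2 cannot be read: the limit of > 5000 nM in this assay, at which 2 of the 4 values shown sit.

Still open, from the compounds shown here alone, is how an unsubstituted amine or an ethylamino group would fare here, and whether any group on this nitrogen can give a lower number than methyl.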